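From methyl to phenyl on a ring nitrogen

The source may hold more compounds than are shown below. What is called first, only, known or untested is meant among the compounds shown, and "the series" means these compounds.

- Compound 1 `CN1CCN(/C=C2\Oc3ccccc3C2=O)CC1`: > 50000 nM
- Compound 2 `CN1CCN(/C=C2\Oc3ccccc3C2=O)C(c2ccccc2)C1`: > 50000 nM

In a functional assay on HCCLM7 cells (Homo sapiens) for antiproliferative activity, read by MTT assay, with a stated time of 72 h (on this read-out lower numbers stand for stronger inhibition and higher numbers for weaker inhibition), compound 1 gives > 50000 nM, which is a limit and not a number. Compound 3 `O=C1/C(=C/N2CCN(c3ccccc3)CC2)Oc2ccccc21` differs from it as follows: phenyl in place of methyl on an amine nitrogen in a ring. Within the data shown here, the only measured step is a step that the two limits leave unreadable from compound 1 to compound 2, with phenyl in place of hydrogen on a saturated ring carbon, so it gives no size to carry over. Compound 2, which also gains a phenyl, remains a limit at > 50000 nM. Little change is therefore expected, perhaps slightly stronger inhibition, and the expected step is an at least 1.2-fold lower number from compound 1 to compound 3 (0.09 log units; that floor lies within the scatter). For compound 3 the estimated value is 40000 nM, with an expected range from 10000 nM to 100000 nM.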

Compound 3, half-maximal inhibitory concentration: 45100 nM
Estimate against measurement, compound 3: 1.1-fold (0.05 log units) below; low and high end bracket the measured number.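

Phenyl in place of methyl on this ring nitrogen gives the first real number in the series in this assay, and the change is an at least 1.1-fold lower number from compound 1 to compound 3 (0.04 log units; that floor lies within the scatter). Compound 1 has only a limit, so the true size of this step cannot be read, and no gain beyond the scatter is shown. Even with phenyl at this position, activity stays weak, with the number near the ceiling of the test: the limit of > 50000 nM in this assay, at which 2 of the 3 values shown sit.

Open, going by these compounds, is how a benzyl group or a longer chain on this nitrogen would behave. Also open, on these data alone, is whether a fluorine or methoxy group on the phenyl ring would move the number.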